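Pyridinyl for Phenyl on the Core of Compound 1

A few compounds are considered here, and "the series" means these few. Any claim that something is new, unique, unknown or untested is made for them only; others in the source may bear on it.

Compound 1 `Nc1c2c(=O)[nH]c(-c3ccccc3)cc2nn1-c1ccccc1` was examined in an assay on isolated protein for inhibition of protein kinase C zeta type (Homo sapiens), read by mobility shift assay, tested at 30 uM (a higher number here means more inhibition at the concentration tested (going by the name of the read-out), a lower number less inhibition), and in that assay compound 1 gives -163%. Two companions carry a methoxy group on an aromatic carbon: compound 2 `COc1ccccc1-c1cc2nn(-c3ccccc3)c(N)c2c(=O)[nH]1` gives 4% in this assay, and compound 3 `COc1ccc(-c2cc3nn(-c4ccccc4)c(N)c3c(=O)[nH]2)cc1` gives 0%. Compound 1 thus stands lowest of the three numbers; the nearest is compound 3 and the furthest is compound 2, both beyond the scatter. The steps from it were large: a number 167 percentage points higher from compound 1 to compound 2 (beyond the scatter) and a number 163 percentage points higher from compound 1 to compound 3 (beyond the scatter), whereas a number 4 percentage points lower from compound 2 to compound 3 (within the scatter) lies within the scatter.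

Compound 4 `Nc1c2c(=O)[nH]c(-c3ccccc3)cc2nn1-c1ccccn1` has not yet been measured. It differs from compound 1 in one place: pyridin-2-yl in place of phenyl on an aromatic nitrogen. Within the data shown here, no measured step alters this position, so none bears directly on the change. What the measured pairs do show is that each single alteration of compound 1 moved the reading sharply upward, toward no inhibition; the direction of the new change is therefore uncertain, but a rise from the strongly negative number of compound 1 is considered the more likely outcome.

Compound 4 is accordingly expected to give -50% in this assay, within a range from -170% to 20%. This estimate implies a step of a number 113 percentage points higher from compound 1 to compound 4 (beyond the scatter), expected to lie beyond the scatter.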

Compound 4, a percentage reported as inhibition, at one concentration (the size of the read-out at that concentration, not a potency): -3%
Compound 4: middle estimate off by 47 percentage points, on the low side; the measured number falls inside the stated range.
By their numbers in this assay, from the lowest: compound 1; then compounds 4, 3 and 2 (each within the scatter of the next).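

In this assay, the group on the aromatic nitrogen proves able to shift the reading on its own: pyridin-2-yl in place of phenyl gives a number 160 percentage points higher from compound 1 to compound 4 (beyond the scatter), where it carries one hydrogen-bond acceptor that phenyl lacks. Until now, only methoxy on an aromatic carbon had been seen to move the number, with a number 167 percentage points higher from compound 1 to compound 2 (beyond the scatter) and a number 163 percentage points higher from compound 1 to compound 3 (beyond the scatter), so a single change at either of these two sites of compound 1 has now produced a large rise, and no compound shown goes against this. Nothing available explains why this exchange at the aromatic nitrogen has so large an effect.

The compounds shown leave open how pyridin-3-yl, pyridin-4-yl or a plain methyl group on that aromatic nitrogen would read, and so whether the result is particular to pyridin-2-yl or comes with the loss of phenyl from this place. They also leave open what pyridin-2-yl on the aromatic nitrogen would give when paired with a 2-methoxyphenyl or 4-methoxyphenyl group on the shared core.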